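This account rests on a few compounds, and the source may have more. Where it says the series, first, only, none or still open, it means among the compounds named here.

Measured compounds in an assay on Cerebral cortex for binding affinity to adenosine receptor A1 (Cavia porcellus), read by radioligand binding; a lower number here means a stronger inhibitor, a higher number a weaker inhibitor:
compound 1 `C=CCn1c(=O)c2[nH]cnc2n(CCC)c1=O` gives 1700 nM;
compound 2 `CCCn1c(=O)n(CCCN(C)C)c(=O)c2[nH]cnc21` gives 43200 nM;
compound 3 `CCCn1c(=O)n(C)c(=O)c2c1ncn2CC(N)=O` gives > 200000 nM.

For compound 3 the value in this assay is a limit of the assay and not a number, the limit being (the limit of > 200000 nM in this assay, at which 1 of the 3 values shown sits). Compound 3 therefore stands at the weak end of the three values shown, with no numerical figure to place it more closely.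

The next compound in the series is compound 4 `CCCn1c(=O)n(C)c(=O)c2c1ncn2CCC(C)=O`. It differs from compound 3 in one place: 2-oxopropyl in place of carbamoyl on a saturated chain carbon bound to an aromatic nitrogen.

Among the measured compounds shown here, the only step measured between two compounds that differ in one place is a 25-fold higher number from compound 1 to compound 2 (1.41 log units; beyond the scatter). That change, though also sited on a saturated chain carbon bound to an aromatic nitrogen, concerns a different group and a different position of the shared core, so it gives no direct guide to the carbamoyl to 2-oxopropyl exchange. For the measured compounds named here, no measured step in this assay bears on the change from compound 3 to compound 4.

Going by the values given here, with compound 3 at a limit and no comparable step, the expectation for compound 4 in this assay is a step of an at least 1.3-fold lower number from compound 3 to compound 4 (0.12 log units; that floor lies within the scatter), with the assay as likely as not to report a limit again. Compound 4 is therefore estimated at 150000 nM, within a range from 30000 nM to 500000 nM.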

Compound 4, inhibition constant: 30000 nM
Beside the measured number, compound 4's estimate is 5.0-fold (0.70 log units) above it, within the range that was stated.
By their numbers in this assay, from the lowest: compound 1; then compounds 4 and 2 (each within the scatter of the next). At a limit, above all of these: compound 3.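

At this place, on a saturated chain carbon bound to an aromatic nitrogen, the exchange of carbamoyl for 2-oxopropyl gives in this assay an at least 6.6-fold lower number from compound 3 to compound 4 (0.82 log units; beyond the scatter), so the group here can shift the reading beyond the scatter, which no earlier comparison showed. Cut one bond further out, the same difference reads carbamoylmethyl to 2-acetylethyl, and the hydrogen-bond donor of carbamoyl leaves with it, so this single step cannot assign the change to the chain, the end group or the donor. The size of the step is only a floor because compound 3 stands at a limit: the limit of > 200000 nM in this assay, at which 1 of the 4 values shown sits.

Open, going by these compounds, is whether the carbonyl of 2-oxopropyl matters at all, which a plain butyl chain at the same place would test, and whether a carboxylic acid or a primary amine at the end of the chain would read any differently. Also open, on these data alone, is how far a longer chain ending in the same ketone would carry the change in this assay.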